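Adding a Second Nitro Group: Expected Cytotoxicity

This account rests on a few compounds, and the source may have more. Where it says the series, first, only, none or still open, it means among the compounds named here.

Among the measured compounds shown here, compound 2 `O=C(NC(=S)Nc1nc2ccccc2s1)c1ccc([N+](=O)[O-])cc1` is the only member of this set with a number in a functional assay on HeLa cells (Homo sapiens) for cytotoxicity, read by MTT assay, with a stated time of 24 h; on this read-out lower numbers stand for stronger inhibition and higher numbers for weaker inhibition: compound 2 gives 62600 nM. Compound 1 `CCCCC(=O)NC(=S)Nc1nc2cc([N+](=O)[O-])ccc2s1` stands in this assay as "not determined" (no result reported). Compound 3 `O=C(NC(=S)Nc1nc2cc([N+](=O)[O-])ccc2s1)c1ccc([N+](=O)[O-])cc1` differs from compound 2 by nitro in place of hydrogen on an aromatic carbon. For the measured compounds named here, no measured pair shows what such a change does here, so nothing beyond a modest shift is anticipated. In this assay the expected step is a 1.4-fold lower number from compound 2 to compound 3 (0.14 log units; within the scatter), of a size that stays within the usual scatter. Compound 3 is therefore estimated at 45000 nM, with a range from 15000 nM to 150000 nM.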

Compound 3, half-maximal inhibitory concentration: 68500 nM
Compound 3: the middle estimate sits 1.5-fold (0.18 log units) below what was measured; the measured number falls inside the stated range.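

In this assay, among the compounds shown here, nitro in place of hydrogen on this aromatic carbon, part of a fused system of two rings, gives a 1.1-fold higher number from compound 2 to compound 3 (0.04 log units; within the scatter), the first measured step at this position. In this pair, the added nitro group therefore does not separate the two compounds. Nothing available gives a reason for this result. Going by these compounds, whether an amine or a carboxylic acid on the same aromatic carbon would set a compound apart from compound 2 stays open. Steps involving compound 1 cannot be read, as it has no number in this assay.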